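Replacing (2-Methoxyphenyl)amino with Benzyloxy on the Carbonyl

The source may hold more compounds than are shown below. What is called first, only, known or untested is meant among the compounds shown, and "the series" means these compounds.

Of the compounds shown here, two have been measured in a functional assay on Shh Light II cells (Mus musculus) for inhibition, read by a luciferase reporter; on this read-out lower numbers stand for stronger inhibition and higher numbers for weaker inhibition. Compound 1 `COc1ccccc1N(C)C(=O)N1CCC(c2nc(-c3ccc4ccccc4n3)no2)CC1` gives 3100 nM, while compound 2 `COc1ccccc1NC(=O)N1CCC(c2nc(-c3ccc4ccccc4n3)no2)CC1`, which carries a hydrogen in place of a methyl on an amide-type nitrogen, gives 410 nM. Among the compounds with values here, that single step, a 7.6-fold lower number from compound 1 to compound 2 (0.88 log units; beyond the scatter), is the only comparison available, and it leaves compound 2 with the lower of the two numbers.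

Compound 3 `O=C(OCc1ccccc1)N1CCC(c2nc(-c3ccc4ccccc4n3)no2)CC1` alters compound 2 at the carbonyl carbon: benzyloxy in place of (2-methoxyphenyl)amino on a carbonyl carbon. As counted, the group that leaves holds one hydrogen-bond donor and the group that enters holds none. Within the data shown here, the one step seen so far points the same way: going from compound 1 to compound 2 supplied a hydrogen on that nitrogen and the number fell, so taking the whole donor-bearing group away is expected to push the number back up, by roughly a comparable amount, although nothing measured tells how benzyloxy itself behaves. Compound 3 is therefore expected to give about 2000 nM in this assay, estimated to lie between 600 nM and 7000 nM. That estimate amounts to an expected step of a 4.9-fold higher number from compound 2 to compound 3 (0.69 log units; beyond the scatter).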

Compound 3, half-maximal inhibitory concentration: > 2500 nM
Compound 3: no number, only a limit; the forecaster's own chance of this, stated with the estimate: 10%; middle value at least 1.2-fold (0.09 log units) from the limit.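

Compound 3 gives no exact number in this assay, only a limit: the limit of > 2500 nM in this assay, at which 1 of the 3 values shown sits.

Even so, the limit is enough to size the change from one side. Putting benzyloxy in place of (2-methoxyphenyl)amino on the carbonyl carbon gives an at least 6.0-fold higher number from compound 2 to compound 3 (0.78 log units; beyond the scatter), so this position does not simply accept any group carrying a six-membered aromatic ring of carbon only, since both groups hold one such ring and they differ clearly in the read-out. The group that leaves holds 1 hydrogen-bond donor and benzyloxy holds 0, which fits the earlier step on the amide-type nitrogen in direction, while the step between compound 1 and compound 3 cannot be read.

Several things change together in this swap, including the nitrogen with its hydrogen, the methoxy group and the link to the aromatic ring, and the compounds shown do not separate them. From the compounds shown here alone, a benzylamino group on the same carbonyl carbon, or a plain phenylamino group, would keep that nitrogen and its hydrogen, and how either behaves remains open, as does how far above its limit compound 3 really lies.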